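This account rests on a few compounds, and the source may have more. Where it says the series, first, only, none or still open, it means among the compounds named here.

Working notes on the series. Compound 1, `CO[C@@H]1CC=C2NN(c3ccc([N+](=O)[O-])cc3)C(=O)CC[C@]2(c2ccccc2)O1`, in a functional assay on HCT-116 cells (Homo sapiens) for cytotoxicity, read by sulforhodamine B assay, with a stated time of 48 h (on this read-out lower numbers stand for stronger inhibition and higher numbers for weaker inhibition), gives 8700 nM. Compound 2, `CO[C@@H]1CC=C2N(c3ccc([N+](=O)[O-])cc3)C(=O)C[C@]2(c2ccccc2)O1`, in this assay gives 8000 nM. Going by the values given here, compound 2 carries the lower of the two numbers recorded so far, with compound 1 its only neighbour; the gap between the two values lies within the scatter, so nothing separates them.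

The next entry is compound 3, `CO[C@@H]1CC=C2N(c3c[nH]c4ccccc34)C(=O)C[C@]2(c2ccccc2)O1`. Relative to compound 2 the change is 1H-indol-3-yl in place of 4-nitrophenyl on an amide-type nitrogen in a ring. Among the compounds with values here, no pair of measured compounds shows this same change, so there is no measured step to lean on; the only guide is that both recorded values sit in the same region. The step from compound 2 to compound 3 in this assay is expected to be small, a 1.3-fold lower number from compound 2 to compound 3 (0.12 log units; within the scatter), with no clear direction beyond the scatter. For compound 3 in this assay the estimate is 6000 nM, in a range from 1500 nM to 25000 nM.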

Compound 3, half-maximal inhibitory concentration: 7130 nM
For compound 3 the middle estimate is 1.2-fold (0.07 log units) below the measured one; measured number inside the range.
By their numbers in this assay, from the lowest: compounds 3, 2 and 1 (each within the scatter of the next).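

On the amide-type nitrogen in a ring, 1H-indol-3-yl in place of 4-nitrophenyl gives a 1.1-fold lower number from compound 2 to compound 3 (0.05 log units; within the scatter) in this assay. Going by these compounds alone, this is the first single-place comparison, and it shows that this position accepts a change from a nitro-bearing six-membered aromatic ring to a fused indole with its hydrogen-bond donor, with no separation in the read-out beyond the scatter. No independent measurement bears on this result, so the data offer no account of it.

The compounds shown leave open how a non-aromatic group on this nitrogen, such as a longer alkyl chain, a primary amine or a carboxylic acid, would read in this assay. They also leave open whether replacing the phenyl group on the shared core would move the number beyond the scatter.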